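Series notes: pyridyl exchange from compound 3 to compound 4

The source may report more compounds than this note shows. Statements on the series, on what has been measured and on what is new or still open speak of the compounds shown alone.

Three compounds of the series carry a measurement in a functional assay on A-375 cells (Homo sapiens) for cytotoxicity, read by MTT assay, with a stated time of 72 h, tested at 30 uM; on this read-out lower numbers stand for less inhibition of growth and higher numbers for more inhibition of growth at the one concentration tested. Compound 1 `Cc1ccnc(/C(N)=N/NC(=S)N2CCSCC2)c1` gives 84.9% in this assay, compound 2 `Cc1ccnc(/C(N)=N/NC(=S)N2CCCCCC2)c1` gives 76.5%, and compound 3 `N/C(=N\NC(=S)N1CCN(c2ccccn2)CC1)c1ccc(F)cn1` gives 73.2%. On these numbers compound 3 sits beneath compound 1 by more than the usual scatter, whereas compound 2 lies within the scatter of compound 3, so no order between compound 2 and compound 3 can be read from the values.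

Compound 4 `Cc1cccc(/C(N)=N/NC(=S)N2CCN(c3ccccn3)CC2)n1` has not been measured. It differs from compound 3 in one place: 6-methylpyridin-2-yl in place of 5-fluoropyridin-2-yl on a carbon with a double bond to nitrogen. Going by the values given here, no pair of measured compounds shows this change, so no measured step can be drawn on. The amine part of compound 3 is kept, and the change touches only the aromatic ring on the carbon with a double bond to nitrogen.

The expectation for compound 4 is a step of a number 1.8 percentage points higher from compound 3 to compound 4 (within the scatter) in this assay, that is, a movement from compound 3 of no more than the scatter, in either direction. On that basis compound 4 is estimated at 75% in this assay, with a range from 60% to 88%.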

Compound 4, percent growth inhibition at one concentration: 74.8%
For compound 4 the middle estimate is 0.2 percentage points above the measured one, within the range that was stated.
By their numbers in this assay, from the lowest: compounds 3, 4, 2 and 1 (each within the scatter of the next, the first and the last beyond it).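

The series now has a measured step at this place, on a carbon with a double bond to nitrogen, with the amine part held constant: in this assay, the exchange of 5-fluoropyridin-2-yl for 6-methylpyridin-2-yl gives a number 1.6 percentage points higher from compound 3 to compound 4 (within the scatter). For this one pair, then, the exchange between these two rings, each with the same count of heavy atoms, does not move growth inhibition beyond the scatter. No measurement on hand accounts for this outcome.

Going by these compounds, the pair covers a single amine part and a single tested concentration, so it remains open whether the same exchange would behave alike with the amine parts of other compounds, or at another concentration. On these data alone, it also remains open how a phenyl ring or a pyridin-2-yl ring carrying a carboxylic acid would read at this place.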